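A few compounds are considered here, and "the series" means these few. Any claim that something is new, unique, unknown or untested is made for them only; others in the source may bear on it.

In a functional assay on HepG2 cells (Homo sapiens), read by MTT assay, with a stated time of 48 h (on this read-out lower numbers stand for stronger inhibition and higher numbers for weaker inhibition), compound 3 `CCN(CC)CCNC(=O)c1ccc(C(CC)(CC)c2ccc(OCC(O)C(C)(C)C)c(C)c2)n1CC` gives 490 nM, within the scatter of compound 1 `CCN(CC)CCNC(=O)c1ccc(C(CC)(CC)c2ccc(OCC(=O)C(C)(C)C)c(C)c2)n1CC` at 620 nM, and both sit above compound 2 `CCn1c(C(=O)NCCN)ccc1C(CC)(CC)c1ccc(OCC(=O)C(C)(C)C)c(C)c1` at 180 nM. Compound 4 `C#CCNC(=O)c1ccc(C(CC)(CC)c2ccc(OCC(O)C(C)(C)C)c(C)c2)n1CC` differs from compound 3 by ethynyl in place of (diethylamino)methyl on a saturated chain carbon bound to an amide-type nitrogen. The closest evidence is a 3.4-fold lower number from compound 1 to compound 2 (0.54 log units; beyond the scatter), a modest step for amino in place of diethylamino on this chain. The other step, a 1.3-fold lower number from compound 1 to compound 3 (0.10 log units; within the scatter), lies within the scatter and leaves this chain untouched. Going by the values given here, no measured compound lacks the chain's amino group, so the direction is uncertain. A modest step of a 1.6-fold lower number from compound 3 to compound 4 (0.21 log units; within the scatter) is expected in this assay. For compound 4 the estimate is 300 nM, with an expected range of 90 nM to 1000 nM.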

Compound 4, half-maximal inhibitory concentration: > 50000 nM
Compound 4 was reported as a limit; the forecaster's own chance of this, stated with the estimate: 5%; middle value at least 160-fold (2.22 log units) away from the limit.
By their numbers in this assay, from the lowest: compound 2; then compounds 3 and 1 (each within the scatter of the next). At a limit, above all of these: compound 4.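

In this assay, ethynyl in place of (diethylamino)methyl on the saturated chain carbon bound to an amide-type nitrogen gives an at least 100-fold higher number from compound 3 to compound 4 (2.00 log units; beyond the scatter), a large step, far beyond the modest 3.4-fold lower number from compound 1 to compound 2 (0.54 log units; beyond the scatter) seen for amino in place of diethylamino. Compounds 1, 2 and 3 all keep an amine on this chain, and compound 4, the only one without it, loses activity sharply. Compound 4 is known only as a limit: the limit of > 50000 nM in this assay, at which 1 of the 4 values shown sits.

Still open, going by these compounds, is whether the loss follows from removing the amine or from introducing the propargyl group. A plain propyl chain and a 2-aminopropyl chain would help separate these two readings.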